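Swapping a Chain for a Methylphenyl Group on Sulfur

The source may report more compounds than this note shows. Statements on the series, on what has been measured and on what is new or still open speak of the compounds shown alone.

Compound 1 `CC(C)(C)NC(=O)NCCS(=O)(=O)NC(=O)c1ccc(Nc2nc(NC3(c4ccc(Cl)cc4)CC3)nc(OCC(F)(F)F)n2)cc1` carries a 2-(((tert-butyl)carbamoyl)amino)ethyl group on a sulfonyl sulfur. In an ADME assay on microsomes from liver (Rattus norvegicus) for metabolic stability, with a stated time of 10 min (a higher number here means that more of the compound is left, a lower number that less of the compound is left), compound 1 gives 93%, which places it second highest among the three measured values. Compound 2 `O=C(NS(=O)(=O)c1ccccc1)c1ccc(Nc2nc(NC3(c4ccc(Cl)cc4)CC3)nc(OCC(F)(F)F)n2)cc1` gives 100%, and compound 3 `CN(C)S(=O)(=O)NC(=O)c1ccc(Nc2nc(NC3(c4ccc(Cl)cc4)CC3)nc(OCC(F)(F)F)n2)cc1` gives 76%. The step of a number 7 percentage points higher from compound 1 to compound 2 (within the scatter) stays within the scatter, whereas the steps of a number 17 percentage points lower from compound 1 to compound 3 (beyond the scatter) and a number 24 percentage points lower from compound 2 to compound 3 (beyond the scatter) are modest drops beyond it. Compound 4 `Cc1ccccc1S(=O)(=O)NC(=O)c1ccc(Nc2nc(NC3(c4ccc(Cl)cc4)CC3)nc(OCC(F)(F)F)n2)cc1` has not yet been measured; it differs from compound 1 in one place: 2-methylphenyl in place of 2-(((tert-butyl)carbamoyl)amino)ethyl on a sulfonyl sulfur. Within the data shown here, the measured step that bears most closely on this change is the one from compound 1 to compound 2, where a phenyl replaces the same chain on the same sulfonyl sulfur and the number stays within the scatter. Compound 4 is therefore expected to show no step beyond the scatter, a number 2 percentage points higher from compound 1 to compound 4 (within the scatter). Compound 4 is estimated at 95%, with a range from 80% to 100%.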

Compound 4, percent of the compound remaining: 100%
For compound 4 the middle estimate is 5 percentage points below the measured one, and the stated range covers the measured number.
By their numbers in this assay, from the lowest: compound 3; then compounds 1, 2 and 4 (each within the scatter of the next).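

On a sulfonyl sulfur, the methyl added to the aromatic ring makes no visible difference in this assay, with no change at the digits printed from compound 2 to compound 4 (within the scatter). The 2-methylphenyl group, with 0 hydrogen-bond donors and 0 hydrogen-bond acceptors, also stays level with the 2-(((tert-butyl)carbamoyl)amino)ethyl chain it replaces, which has both, giving a number 7 percentage points higher from compound 1 to compound 4 (within the scatter), while the swap for dimethylamino gives a number 24 percentage points higher from compound 3 to compound 4 (beyond the scatter). Nothing at hand explains these numbers.

The compounds shown leave open whether an aromatic ring is needed on the sulfur at all, and a plain methyl or a pyridine ring there would test that against phenyl and dimethylamino. Also open, on these data alone, is whether a chlorine or a methoxy group in place of the added methyl would stay within the scatter of compound 2.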